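Bromo to methyl on the aromatic carbon: expected step

A few compounds are considered here, and "the series" means these few. Any claim that something is new, unique, unknown or untested is made for them only; others in the source may bear on it.

Compound 2 `COc1cc2c(cc1OC)C(CC(=O)Nc1ccc(Br)cc1)CC2` gives 46.3% in a functional assay on the whole organism (strain Wistar) for inhibition, with Rattus norvegicus as the target, read by paw edema, with a stated time of 6 h, at a dose of 100 mg/kg; on this read-out higher numbers stand for more inhibition at the one dose given (going by the name of the read-out) and lower numbers for less inhibition. Among the compounds with values here, the only other compound measured, compound 1 `COc1cc2c(cc1OC)C(CC(=O)Nc1cccc(Cl)c1)CC2`, gives 38.9%, and the step of a number 7.4 percentage points higher from compound 1 to compound 2 (within the scatter) stays within the scatter, so the two stand together. Compound 3 `COc1cc2c(cc1OC)C(CC(=O)Nc1ccc(C)cc1)CC2` differs from compound 2 by methyl in place of bromo on an aromatic carbon. Within the data shown here, the one measured step concerns a different change and was itself within the scatter, so no measured step speaks to this swap; no step beyond the scatter is expected in this assay, in either direction. Compound 3 is estimated at 42%, with a range from 26% to 58%. For compound 3 the expected step is a number 4.3 percentage points lower from compound 2 to compound 3 (within the scatter).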

Compound 3, a percentage reported as inhibition, in the whole organism at one dose (the size of the read-out at that dose, not a potency): 37%
Compound 3: middle estimate off by 5 percentage points, on the high side; measured number inside the range.
By their numbers in this assay, from the lowest: compounds 3, 1 and 2 (each within the scatter of the next).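

In this assay, methyl in place of bromo on this aromatic carbon gives a number 9.3 percentage points lower from compound 2 to compound 3 (within the scatter), so this position now has a measured step, and at this dose the two groups cannot be told apart. The second step, a number 1.9 percentage points lower from compound 1 to compound 3 (within the scatter), shows that 4-methylphenyl and 3-chlorophenyl cannot be told apart either, and the three compounds stand together. No available evidence bears on this result.

Still open, going by these compounds, is whether an amine or a carboxylic acid on this aromatic carbon would give a step beyond the scatter.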